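Aryl swap on the shared core: compound 3 to compound 4

A few compounds are considered here, and "the series" means these few. Any claim that something is new, unique, unknown or untested is made for them only; others in the source may bear on it.

Measured so far in a functional assay, read by spectrophotometry, with a stated time of 15 min; on this read-out higher numbers stand for weaker inhibition and lower numbers for stronger inhibition:
compound 1 `Cc1nc2c3ccccc3ccc2c2nc3c(ccc4ccccc43)c(-c3ccccc3Cl)c12`: 74.6 ug/mL
compound 2 `Cc1nc2c3ccccc3ccc2c2nc3c(ccc4ccccc43)c(-c3cc([N+](=O)[O-])ccc3N)c12`: 43.3 ug/mL
compound 3 `Cc1nc2c3ccccc3ccc2c2nc3c(ccc4ccccc43)c(-c3cccc4ccccc34)c12`: 64.3 ug/mL

Compound 3 sits second highest of the three numbers. Its nearest neighbour is compound 1, with a 1.2-fold lower number from compound 1 to compound 3 (0.06 log units; within the scatter), and its furthest is compound 2, with a 1.5-fold higher number from compound 2 to compound 3 (0.17 log units; within the scatter); both steps are within the scatter, so no order among the three can be claimed.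

Compound 4 `Cc1nc2c3ccccc3ccc2c2nc3c(ccc4ccccc43)c(-c3ccc(O)cc3)c12` is not yet measured. It differs from compound 3 in one place: 4-hydroxyphenyl in place of naphthalen-1-yl on an aromatic carbon.

Within the data shown here, the steps that bear on this change are the two aryl swaps at the same position already in hand, a 1.2-fold lower number from compound 1 to compound 3 (0.06 log units; within the scatter) and a 1.5-fold higher number from compound 2 to compound 3 (0.17 log units; within the scatter), and also a 1.7-fold lower number from compound 1 to compound 2 (0.24 log units; within the scatter); every one of them lies within the scatter. Three different aryl groups at this position gave numbers that cannot be told apart, so the expectation for a fourth aryl group is no step beyond the scatter in either direction. The step expected from compound 3 to compound 4 is a 1.1-fold lower number from compound 3 to compound 4 (0.03 log units; within the scatter). Compound 4 is therefore estimated at 60 ug/mL, with a range from 30 ug/mL to 120 ug/mL.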

Compound 4, half-maximal inhibitory concentration: 44.1 ug/mL
Compound 4: the middle estimate sits 1.4-fold (0.13 log units) above what was measured; the range from low to high includes it.
By their numbers in this assay, from the lowest: compounds 2, 4, 3 and 1 (each within the scatter of the next).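

In this assay, the step from a group with 2 six-membered aromatic rings and no hydrogen-bond donor or acceptor to one with a single such ring, 1 hydrogen-bond donor and 1 hydrogen-bond acceptor is a 1.5-fold lower number from compound 3 to compound 4 (0.16 log units; within the scatter), so neither difference shifts the number beyond the scatter at this position. The other two comparisons agree, with a 1.0-fold higher number from compound 2 to compound 4 (0.01 log units; within the scatter) and a 1.7-fold lower number from compound 1 to compound 4 (0.23 log units; within the scatter), and the four aryl groups now shown at this position cannot be told apart. No supporting evidence bears on why these numbers stay so close.

From the compounds shown here alone, all four compounds carry an aryl group here, so a saturated group such as cyclohexyl or morpholine remains open. Also open, going by these compounds, is whether a carboxylic acid or an amine on the phenyl ring would give a step beyond the scatter.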